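The compounds below may be only part of what the source reports. "The series", "measured", "known", "first", "only" and "open" are said of these compounds alone.

Three measured compounds share one core and differ only in the group attached to the carbonyl carbon of the amide. Compound 1 `COc1cccc2c1c(NS(=O)(=O)c1ccc(Cl)s1)nn2Cc1cccc(CNC(=O)C2CCO2)c1` carries an oxetan-2-yl group there, compound 2 `COc1cccc2c1c(NS(=O)(=O)c1ccc(Cl)s1)nn2Cc1cccc(CNC(=O)C2CCOCC2)c1` an oxan-4-yl group, and compound 3 `COc1cccc2c1c(NS(=O)(=O)c1ccc(Cl)s1)nn2Cc1cccc(CNC(=O)C(C)(C)N)c1` a 1-amino-1-methylethyl group. In a functional assay on CHO cells for antagonist activity at C-C chemokine receptor type 4 (Homo sapiens), read by GTPgammaS binding (a higher number here means a weaker inhibitor, a lower number a stronger inhibitor), compound 1 gives 31.6 nM, compound 2 gives 31.6 nM and compound 3 gives 15.9 nM. Compound 3 thus has the lowest of the three numbers, yet no gap reaches beyond the scatter: no change at the digits printed from compound 1 to compound 2 (within the scatter), a 2.0-fold lower number from compound 1 to compound 3 (0.30 log units; within the scatter) and a 2.0-fold lower number from compound 2 to compound 3 (0.30 log units; within the scatter).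

Compound 4 `COc1cccc2c1c(NS(=O)(=O)c1ccc(Cl)s1)nn2Cc1cccc(CNC(=O)[C@@H]2CCCCN2)c1` continues the same series: piperidin-2-yl in place of 1-amino-1-methylethyl on a carbonyl carbon. All three measured steps vary this very position, exchanging saturated oxygen rings and an open amine-bearing group, and none of them moved the number beyond the scatter. The change to compound 4 brings the nitrogen back inside a six-membered ring, a variation of the same kind as those already seen. The account therefore expects no step beyond the scatter in this assay, with the number for compound 4 estimated to lie close to that of compound 3, as a 1.3-fold higher number from compound 3 to compound 4 (0.10 log units; within the scatter). Compound 4 is accordingly expected to give about 20 nM, with a range from 8 nM to 50 nM.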

Compound 4, half-maximal inhibitory concentration: 15.9 nM
Compound 4: middle estimate off by 1.3-fold (0.10 log units), on the high side; measured number inside the range.
By their numbers in this assay, from the lowest: compounds 3, 4, 1 and 2 (each within the scatter of the next).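

In this assay, the place on the carbonyl carbon also accommodates a six-membered non-aromatic ring with one nitrogen and one defined stereocentre, and exchanging the open 1-amino-1-methylethyl group for this piperidin-2-yl group gives no change at the digits printed from compound 3 to compound 4 (within the scatter). Against the two saturated oxygen rings, the piperidin-2-yl group shows a 2.0-fold lower number from compound 2 to compound 4 (0.30 log units; within the scatter) and a 2.0-fold lower number from compound 1 to compound 4 (0.30 log units; within the scatter), so all four groups at this place now lie within the scatter of one another. Nothing available bears on why these groups read alike, and no explanation can be given for it.

Going by these compounds, the piperidin-2-yl group appears here in a single configuration, so the reading of its mirror-image form remains open, as does that of the same ring carrying a methyl group on its nitrogen. Also open is whether a carboxylic acid, a phenyl ring or a longer chain on this carbonyl carbon would move the number beyond the scatter, since the four groups shown do not settle how far this tolerance extends.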